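Removing bromo and capping the amide-side nitrogen: compound 4

The compounds below may be only part of what the source reports. "The series", "measured", "known", "first", "only" and "open" are said of these compounds alone.

compound 1, `COc1ccc(Cn2cc(/C=N\NC(=O)c3c[nH]c4ccccc34)c3cc(OC)ccc32)cc1`: 19100 nM
compound 2, `COc1ccc(Cn2cc(/C=N\NC(=O)c3c[nH]c4ccc(Br)cc34)c3cc(OC)ccc32)cc1`: 84400 nM
compound 3, `COc1ccc2c(c1)c(/C=N\NC(=O)c1c[nH]c3ccc(Br)cc13)cn2Cc1ccc(Cl)cc1`: 57000 nM

Of the compounds shown here, three have been measured in a functional assay on DU-145 cells (Homo sapiens) for cytotoxicity; on this read-out lower numbers stand for stronger inhibition and higher numbers for weaker inhibition. Compound 3 stands second highest of the three numbers. Its nearest neighbour is compound 2, and the step of a 1.5-fold lower number from compound 2 to compound 3 (0.17 log units; within the scatter) lies within the scatter, so the two cannot be ordered. Compound 1 gives the lowest number, and its gap to compound 3 is beyond the scatter.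

The next compound, compound 4 `COc1ccc2c(c1)c(/C=N\NC(=O)c1cn(C)c3ccccc13)cn2Cc1ccc(Cl)cc1`, differs from compound 3 in one place: 1-methyl-1H-indol-3-yl in place of 5-bromo-1H-indol-3-yl on a carbonyl carbon. Two things happen at once. For the measured compounds named here, the bromo leaves, and the only measured step that bears on this is a 4.4-fold higher number from compound 1 to compound 2 (0.65 log units; beyond the scatter), where adding bromo raised the number modestly; reversing it should lower the number by about as much. Going by the values given here, the methyl that enters on the ring nitrogen has no precedent among the measured compounds, so its effect is unknown. Compound 4 is therefore expected to show a modestly lower number, a step of a 3.8-fold lower number from compound 3 to compound 4 (0.58 log units; beyond the scatter). The estimate for compound 4 in this assay is 15000 nM, with a range from 5000 nM to 60000 nM.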

Compound 4, half-maximal inhibitory concentration: 93000 nM
Estimate against measurement, compound 4: 6.2-fold (0.79 log units) below; the measured number lies above the stated range.
By their numbers in this assay, from the lowest: compound 1; then compounds 3, 2 and 4 (each within the scatter of the next).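

In this assay, 1-methyl-1H-indol-3-yl in place of 5-bromo-1H-indol-3-yl on the carbonyl carbon gives a 1.6-fold higher number from compound 3 to compound 4 (0.21 log units; within the scatter), so compound 3 and compound 4 cannot be ordered. The earlier step for bromo alone, a 4.4-fold higher number from compound 1 to compound 2 (0.65 log units; beyond the scatter), lies beyond the scatter, yet a step of that size does not appear in this exchange, where bromo leaves, a methyl enters and the hydrogen-bond donor of the leaving group is lost. Nothing at hand accounts for this result.

The compounds shown do not separate the share of the bromo from that of the methyl, since 1H-indol-3-yl is not shown with the rest of compound 3. They also leave open how a larger group such as 1-ethyl-1H-indol-3-yl would read at this carbonyl carbon.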